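The source may hold more compounds than are shown below. What is called first, only, known or untested is meant among the compounds shown, and "the series" means these compounds.

Measured so far in an assay on membranes from CHO cells for displacement of a labelled ligand from adenosine receptor A1 (Homo sapiens), read by scintillation counting, with a stated time of 60 min, tested at 1 uM; on this read-out lower numbers stand for less inhibition and higher numbers for more inhibition at the one concentration tested (going by the name of the read-out):
compound 1 `CC1=C(C(=O)C2CC2)C(c2ccoc2)NC(=O)N1` gives 1%
compound 2 `CC1=C(C(N)=O)C(c2ccoc2)NC(=O)N1` gives 1%
compound 3 `CC1=C(C(=O)SC(C)C)C(c2ccoc2)NC(=O)N1` gives 9%

The three numbers sit close together. Compound 3 shows the top figure of the three, but the steps of a number 8 percentage points higher from compound 1 to compound 3 (within the scatter) and a number 8 percentage points higher from compound 2 to compound 3 (within the scatter) both stay within the scatter, so no order among the three compounds can be claimed; the step of no change at the digits printed from compound 1 to compound 2 (within the scatter) likewise shows nothing beyond the scatter. Every measured step swaps the group on the carbonyl carbon of the shared core, and none of them moves the read-out.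

Compound 4 `CCC(CC)OC(=O)C1=C(C)NC(=O)NC1c1ccoc1` continues that line of substitution: (pentan-3-yl)oxy in place of isopropylsulfanyl on a carbonyl carbon. Among the compounds with values here, the steps that bear on this change are those same three exchanges at the carbonyl carbon, all within the scatter, and none of them involved an oxygen-linked group or a chain of this length, so the new group is not covered directly by any measured pair. With nothing in the series moving the read-out, the step is expected to stay within the scatter as well: a number 4 percentage points lower from compound 3 to compound 4 (within the scatter). Compound 4 is therefore estimated at 5%, with a range from -5% to 15% in this assay.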

Compound 4, a percentage reported as inhibition, at one concentration (the size of the read-out at that concentration, not a potency): 17%
Compound 4: the middle estimate sits 12 percentage points below what was measured; the whole stated range lies below it.
By their numbers in this assay, from the lowest: compounds 1, 2, 3 and 4 (each within the scatter of the next, the first and the last beyond it).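

In this assay, the group on a carbonyl carbon gives its first steps beyond the scatter, a number 16 percentage points higher from compound 2 to compound 4 (beyond the scatter) and a number 16 percentage points higher from compound 1 to compound 4 (beyond the scatter), both with (pentan-3-yl)oxy entering, whereas the exchanges among amino, cyclopropyl and isopropylsulfanyl all stayed within it. The remaining step, a number 8 percentage points higher from compound 3 to compound 4 (within the scatter), stays within the scatter, so replacing isopropylsulfanyl with (pentan-3-yl)oxy shows no separate effect, and compound 3 remains within the scatter of every other compound in the series. No supporting data accompany these steps to account for them.

The compounds shown do not separate the oxygen link from the five-carbon chain of (pentan-3-yl)oxy, and an isopropoxy group or a pentan-3-ylsulfanyl group on the same carbonyl carbon would be needed to tell the two apart. Also open, going by these compounds, is how a longer straight alkoxy chain, a benzyloxy group or a carboxylic acid would read at this place, and whether the readings at this one concentration would correspond to any order of potency.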